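The compounds below may be only part of what the source reports. "The series", "measured", "known", "first", "only" and "open" are said of these compounds alone.

Measured compounds:
- compound 1 `Cc1cc(Nc2cc(-c3ccccc3)[nH]n2)n2nc(SCc3c(Cl)cccc3Cl)nc2n1` — 39600 nM
- compound 2 `Cc1cc(Nc2cc(-c3cccs3)[nH]n2)n2nc(SCc3ccc(Br)cc3)nc2n1` — 38700 nM

In an ADME assay on GES1 cells (Homo sapiens) for inhibition, read by MTT assay, with a stated time of 72 h (a higher number here means a weaker inhibitor, a lower number a stronger inhibitor), compound 1 gives 39600 nM. In this assay compound 2 gives 38700 nM. The two numbers lie within the usual scatter of each other, so compound 1 cannot be told apart from compound 2 on these measurements; it stands at the same level, and no ordering between them can be read from the data. Among the compounds with values here, the two compounds also differ in more than one place, so no single step between measured compounds is available to guide a prediction.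

Compound 3 `Cc1cc(Nc2cc(-c3ccccc3)[nH]n2)n2nc(SCc3cccc4ccccc34)nc2n1` shares the core of compound 1 and differs from it in one place: naphthalen-1-yl in place of 2,6-dichlorophenyl on a saturated chain carbon bound to a sulfur. Within the data shown here, nothing measured so far speaks to this particular exchange. Both measured compounds sit at a similar level despite different groups on the saturated chain carbon bound to the sulfur, so the expectation for compound 3 is a step of a 1.1-fold lower number from compound 1 to compound 3 (0.04 log units; within the scatter), not beyond the scatter. Compound 3 is therefore estimated at 36000 nM, with a range from 12000 nM to 100000 nM.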

Compound 3, half-maximal inhibitory concentration: 36300 nM
Compound 3: middle estimate off by 1.0-fold (0.00 log units), on the low side, within the range that was stated.
By their numbers in this assay, from the lowest: compounds 3, 2 and 1 (each within the scatter of the next).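

In this assay, within the data shown here, putting naphthalen-1-yl in place of 2,6-dichlorophenyl on a saturated chain carbon bound to a sulfur gives a 1.1-fold lower number from compound 1 to compound 3 (0.04 log units; within the scatter) and so provides the first reading of a change at a single place. At this position, a group of 10 heavy atoms with 2 six-membered aromatic rings of carbon only and no chlorine thus leaves compound 3 indistinguishable from compound 1, which carries a group of 8 heavy atoms with one such ring and 2 chlorine atoms. No supporting evidence is available to explain why these two groups give the same level.

As far as these compounds go, it remains open whether this position would also tolerate a group of a different kind on the same saturated chain carbon, such as an amine, a carboxylic acid or a longer alkyl chain, or whether one of these would produce a step beyond the scatter. From the compounds shown here alone, it is also open whether the same exchange of 2,6-dichlorophenyl for naphthalen-1-yl would read the same way on a core other than that of compound 1.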